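Pyridinylmethyl pyrrolidine glycine series: ring-nitrogen acyl variation

This account rests on a few compounds, and the source may have more. Where it says the series, first, only, none or still open, it means among the compounds named here.

Measured compounds:
compound 1, `Cc1cc(C)c(C(=O)N[C@@H](CNC(=O)CO[C@@H]2C[C@@H](CNc3ccccn3)N(C(=O)OCc3ccccc3)C2)C(=O)O)c(C)c1`, 3.5 nM
compound 2, `COc1ccnc(NC[C@@H]2C[C@@H](OCC(=O)NC[C@H](NC(=O)C3(C)CCCCC3)C(=O)O)CN2C(=O)CC(C)(C)C)c1`, 0.55 nM
compound 3, `Cc1cc(C)c(S(=O)(=O)N[C@@H](CNC(=O)CO[C@@H]2C[C@@H](CNc3ccccn3)N(C(=O)CCc3ccccc3)C2)C(=O)O)c(C)c1`, 25 nM

In an assay on a protein complex for inhibition of integrin alpha-5/beta-1 (Homo sapiens), read by ELISA (on this read-out lower numbers stand for stronger inhibition and higher numbers for weaker inhibition), compound 3 stands at the highest of the three numbers; compound 1 gives 3.5 nM and compound 2 gives 0.55 nM, both gaps beyond the scatter. Compound 4, `COC(=O)N1C[C@H](OCC(=O)NC[C@H](NS(=O)(=O)c2c(C)cc(C)cc2C)C(=O)O)C[C@H]1CNc1ccccn1`, differs from compound 3 in one place: methoxy in place of phenethyl on a carbonyl carbon. Among the compounds with values here, no pair of measured compounds isolates this change, so the step is judged from the ring-nitrogen groups seen across compounds 1 to 3 only. The expected step of a 1.3-fold lower number from compound 3 to compound 4 (0.10 log units; within the scatter) is small, in no firm direction, and likely within the scatter. Compound 4 is estimated at 20 nM, range 6 nM to 70 nM.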

Compound 4, half-maximal inhibitory concentration: 15 nM
Compound 4: the middle estimate sits 1.3-fold (0.12 log units) above what was measured; the range from low to high includes it.
By their numbers in this assay, from the lowest: compound 2; then compound 1; then compounds 4 and 3 (each within the scatter of the next).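

In this assay, within the data shown here, the step to methoxy in place of phenethyl on a carbonyl carbon is a 1.7-fold lower number from compound 3 to compound 4 (0.22 log units; within the scatter), the first step that isolates this position. With the shared core held constant, the number stays within the scatter even as the six-membered aromatic ring of phenethyl leaves, so that ring is not needed to hold this level of inhibition in this pair. No data on hand give a reason for this.

Still open, from the compounds shown here alone, is whether a primary amine or a carboxylic acid at the end of a longer chain on this carbonyl carbon would keep the number. Also open, going by these compounds, is whether methoxy behaves the same way with a different group in place of the trimethylphenyl sulfonyl.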